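Swapping one aryl group on a lipophilicity scale

The source may report more compounds than this note shows. Statements on the series, on what has been measured and on what is new or still open speak of the compounds shown alone.

Measured in a physicochemical assay for lipophilicity, read by HPLC, at pH 7.5; on this read-out lower numbers stand for lower lipophilicity and higher numbers for higher lipophilicity:
Compound 1 `CC[C@@H](Nc1c(C#N)c(-c2ccc(-c3ccc(Cl)cc3)cc2)nc2cnccc12)C(N)=O`: 3.1
Compound 2 `CC[C@@H](Nc1c(C#N)c(-c2ccc(-c3ccccc3NC)cc2)nc2cnccc12)C(N)=O`: 2.5

Compound 2 stands lower of the two, at 2.5 on this scale. Compound 3 `CC[C@@H](Nc1c(C#N)c(-c2ccc(-c3cccc(OC)c3)cc2)nc2cnccc12)C(N)=O` has 3-methoxyphenyl in place of 2-(methylamino)phenyl on an aromatic carbon, a swap counted as 3-methoxyphenyl in place of 2-(methylamino)phenyl on an aromatic carbon here. Within the data shown here, only one measured step bears on this, the modest a number 0.60 log units lower from compound 1 to compound 2 (beyond the scatter) at that same place. Among the measured compounds shown here, with 2-(methylamino)phenyl gone, part of that drop is expected to return, though only one step supports this. The expected rise is a number 0.40 log units higher from compound 2 to compound 3 (beyond the scatter) in this assay overall. For compound 3 the estimated value is 2.9, with an expected range of 2.5 to 3.3 around it.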

Compound 3, distribution coefficient: 2.7
Estimate against measurement, compound 3: 0.20 log units above; low and high end bracket the measured number.
By their numbers in this assay, from the lowest: compounds 2 and 3 (each within the scatter of the next); then compound 1.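

In this assay, 2-(methylamino)phenyl, with 1 hydrogen-bond donor, and 3-methoxyphenyl, with 0, are not separated at this place: the step is a number 0.20 log units higher from compound 2 to compound 3 (within the scatter). The step from 4-chlorophenyl is larger, a number 0.40 log units lower from compound 1 to compound 3 (beyond the scatter), so both replacements shown now sit apart from compound 1. Nothing available explains these numbers.

Whether the gap to compound 1 follows the chlorine itself remains unsettled. On these data alone, how an unsubstituted phenyl or a phenyl bearing a carboxylic acid would compare at this place also remains open.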